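Compound 4 against compound 1: methoxy in place of methyl

The compounds below may be only part of what the source reports. "The series", "measured", "known", "first", "only" and "open" are said of these compounds alone.

Measured so far in an assay on isolated protein for inhibition of kynurenine 3-monooxygenase (Rattus norvegicus); on this read-out lower numbers stand for stronger inhibition and higher numbers for weaker inhibition:
compound 1 `Cc1ccc(S(=O)(=O)Nc2nc(-c3cccc([N+](=O)[O-])c3)cs2)cc1` gives 48 nM
compound 2 `COc1ccc(S(=O)(=O)Nc2nc(-c3cc(C(F)(F)F)ccc3F)cs2)cc1OC` gives 39 nM
compound 3 `O=[N+]([O-])c1cccc(-c2cc(-c3nn[nH]n3)no2)c1` gives 1160 nM

Compound 1 holds the second highest of the three numbers. Compound 2 sits nearest, within the usual scatter, so no order between the two can be claimed. Compound 3 is furthest, with a clearly higher number, beyond the scatter, and is therefore the weaker inhibitor of the three in this assay.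

Compound 4 `COc1ccc(S(=O)(=O)Nc2nc(-c3cccc([N+](=O)[O-])c3)cs2)cc1` differs from compound 1 in one place: methoxy in place of methyl on an aromatic carbon.

Compound 2 already carries methoxy on its six-membered aromatic ring and gives 39 nM, a number within the scatter of compound 1. No step beyond the scatter is therefore expected in this assay, in either direction. The estimated step of a 1.1-fold lower number from compound 1 to compound 4 (0.03 log units; within the scatter) is expected to stay within the scatter. Compound 4 is estimated at 45 nM, with a range from 20 nM to 100 nM.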

Compound 4, half-maximal inhibitory concentration: 51 nM
Estimate against measurement, compound 4: 1.1-fold (0.05 log units) below; the measured number falls inside the stated range.
By their numbers in this assay, from the lowest: compounds 2, 1 and 4 (each within the scatter of the next); then compound 3.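

In this assay, among the compounds shown here, 4-methylphenyl to 4-methoxyphenyl gives a 1.1-fold higher number from compound 1 to compound 4 (0.03 log units; within the scatter), the only comparison so far that changes a single place. For the compounds shown here, with the rest of compound 1 held fixed, this position, para to a large group, takes methoxy in place of methyl with no step that can be told from the scatter. Nothing shown bears on the reason for this. As far as these compounds go, it remains open whether an amine, a carboxylic acid or a longer chain such as butoxy at this position would also leave the number within the scatter.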